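Trifluoro salicylic acid series: removing one ring fluorine

The source may report more compounds than this note shows. Statements on the series, on what has been measured and on what is new or still open speak of the compounds shown alone.

Of the compounds shown here, three of the shared core have been measured in a toxicity assay on the whole organism (strain CD-1) for cytotoxicity, with Mus musculus as the target, with a stated time of 14 days, at a dose of 150 mg/kg by the intraperitoneal route; a higher number here means a weaker effect of the compound at the dose given, a lower number a stronger effect. Compound 1 `COc1c(C(=O)O)cc(F)c(F)c1F` gives 80%. Compound 2 `O=C(O)c1cc(F)c(F)c(F)c1O` gives 66%, and compound 3 `O=C(O)c1ccc(F)c(F)c1O` gives 66%. Compound 2 stands level with compound 3 at the digits shown, and the two together give the lowest numbers of the set; the nearest neighbour of compound 2 is compound 3, the furthest is compound 1, with a number 14 percentage points lower from compound 1 to compound 2 (beyond the scatter) for hydrogen in place of methyl on an oxygen on an aromatic ring.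

Compound 4 `O=C(O)c1cc(F)c(F)cc1O` has not yet been measured in this assay. Among the compounds with values here, it differs from compound 2 as follows: hydrogen in place of fluoro on an aromatic carbon The one measured step that bears on this change is the step from compound 2 to compound 3, also hydrogen in place of fluoro on an aromatic carbon, which gave no change at the digits printed from compound 2 to compound 3 (within the scatter). The earlier replacement of a fluoro group by hydrogen on the ring left the read-out unchanged, and the change to compound 4 is of the same kind at a different ring carbon, so no step beyond the scatter is expected in this assay, in either direction.

Compound 4 is therefore expected to give 66% in this assay, with a range of 52% to 80%. The estimate implies a step of no change at the digits printed from compound 2 to compound 4 (within the scatter), within the scatter.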

Compound 4, a percentage reported as activity, at one dose (the size of the read-out at that dose, not a potency): 66%
Compound 4: the middle estimate sits on the measured number at the digits printed; low and high end bracket the measured number.
By their numbers in this assay, from the lowest: compounds 2, 3 and 4 (each within the scatter of the next); then compound 1.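

In this assay the change from fluoro to hydrogen at the ring carbon ortho to a hydroxy group and meta to a carboxy group gives no change at the digits printed from compound 2 to compound 4 (within the scatter) and so does not move the read-out beyond the scatter. Within the data shown here, until now, the only reading of this change came from no change at the digits printed from compound 2 to compound 3 (within the scatter) at another ring carbon, so the flat result now holds at two separate ring carbons of compound 2, though only for this one change and only at the single dose tested. No measurement at hand bears on why the read-out stays flat at this ring carbon.

Hydrogen and fluoro are the only two groups compared at this ring carbon, so it remains open whether an amine, a methoxy group or a longer chain placed there would leave the read-out where it stands. From the compounds shown here alone, the step for hydrogen in place of methyl on the oxygen is known only from a number 14 percentage points lower from compound 1 to compound 2 (beyond the scatter) with all three fluoro groups in place, and whether it carries over to the core of compound 4 remains open.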